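Aryl variation on the carbonyl carbon: cytotoxicity at one concentration

The source may report more compounds than this note shows. Statements on the series, on what has been measured and on what is new or still open speak of the compounds shown alone.

Measured compounds:
compound 1, `COc1cc(-c2cc(/C=C/C(=O)c3ccc(N)cc3)[nH]n2)cc(OC)c1OC`, gives 91% in a functional assay on RXF 393 cells (Homo sapiens) for cytotoxicity, read by sulforhodamine B assay, with a stated time of 48 h, tested at 0.01 uM; on this read-out higher numbers stand for a weaker effect at the one concentration tested and lower numbers for a stronger effect
compound 2, `COc1ccc(C(=O)/C=C/c2cc(-c3cc(OC)c(OC)c(OC)c3)n[nH]2)cc1OC`, gives 100% in this assay

In this assay compound 2 stands at the highest of the two numbers recorded, and its nearest neighbour is compound 1. Within the data shown here, the single step between them, a number 9 percentage points higher from compound 1 to compound 2 (within the scatter), lies within the scatter, so the two numbers are taken as alike; both sit close to the top of the read-out at the one concentration tested.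

Compound 3, `COc1cc(-c2cc(/C=C/C(=O)c3ccc(F)c(F)c3)[nH]n2)cc(OC)c1OC`, is the next member. It differs from compound 2 in one place: 3,4-difluorophenyl in place of 3,4-dimethoxyphenyl on a carbonyl carbon.

Among the measured compounds shown here, the only measured step that bears on this change is the exchange on the same carbonyl carbon from compound 1 to compound 2, which stayed within the scatter. For the measured compounds named here, the 3,4-difluorophenyl group that enters has no measured counterpart, so nothing in the numbers points to a move in either direction, and no step beyond the scatter is expected in this assay.

The step from compound 2 to compound 3 is expected to be a number 4 percentage points lower from compound 2 to compound 3 (within the scatter). Compound 3 is estimated at 96%, within 82% to 108%.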

Compound 3, a percentage reported as activity, at one concentration (the size of the read-out at that concentration, not a potency): 94%
Compound 3: the middle estimate sits 2 percentage points above what was measured, within the range that was stated.
By their numbers in this assay, from the lowest: compounds 1, 3 and 2 (each within the scatter of the next).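

In this assay, the exchange of 3,4-dimethoxyphenyl for 3,4-difluorophenyl on the carbonyl carbon gives a number 6 percentage points lower from compound 2 to compound 3 (within the scatter), and the exchange of 4-aminophenyl for the same group gives a number 3 percentage points higher from compound 1 to compound 3 (within the scatter), so all three aryl groups now read as alike. The series at this position thus extends to a fluorinated aryl group, and even a change from 2 hydrogen-bond acceptors on the group to 0 leaves the read-out within the scatter at the one concentration tested. No independent measurement bears on this result, so the numbers show only the absence of a separable step and offer no account of it.

The compounds shown leave open whether any group on this carbonyl carbon can bring the read-out clearly down from the top of the range at this concentration, for example a carboxylic acid on the phenyl ring, a trifluoromethyl group or a pyridine ring in place of the phenyl ring. They also leave open whether the three aryl groups would stay alike at a higher concentration, where a full concentration series could separate them.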